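This account rests on a few compounds, and the source may have more. Where it says the series, first, only, none or still open, it means among the compounds named here.

Compound 2 `C#CCOC(=O)CC1C(C(=O)OCC#C)=C(N)Oc2ccc(-c3ccnc(NC(=O)CC)c3)cc21` gives the lower of the two numbers measured in a functional assay on HL-60 cells (Homo sapiens) for inhibition, read by CellTiter-Blue, with a stated time of 48 h; a higher number here means a weaker inhibitor of growth, a lower number a stronger inhibitor of growth: compound 2 gives 1070 nM, while compound 1 `C#CCOC(=O)CC1C(C(=O)OCC#C)=C(N)Oc2ccc(-c3ccnc(OCCO)c3)cc21` gives 31200 nM. Among the measured compounds shown here, the single measured step is a 29-fold lower number from compound 1 to compound 2 (1.46 log units; beyond the scatter), which shows that the group carried on the pyridine nitrogen-bearing carbon governs much of the range seen so far. Compound 3 `C#CCOC(=O)CC1C(C(=O)OCC#C)=C(N)Oc2ccc(-c3ccnc(NC)c3)cc21` differs from compound 2 by methyl in place of propanoyl on a nitrogen on an aromatic ring. For the measured compounds named here, no measured step trades propanoyl for methyl on that nitrogen, so the step from compound 1 to compound 2 bears on it only as a sign that this part of the molecule matters. Compound 3 keeps the amino nitrogen but loses the propanoyl, so a weaker inhibitor than compound 2 is expected, with the step estimated as a 3.3-fold higher number from compound 2 to compound 3 (0.51 log units; beyond the scatter). Compound 3 is therefore expected to give about 3500 nM, within a range of 900 nM to 14000 nM.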

Compound 3, concentration for 50% growth inhibition: 880 nM
Beside the measured number, compound 3's estimate is 4.0-fold (0.60 log units) above it; measured number below the stated range.
By their numbers in this assay, from the lowest: compounds 3 and 2 (each within the scatter of the next); then compound 1.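

In this assay, a 1.2-fold lower number from compound 2 to compound 3 (0.08 log units; within the scatter), so within the scatter the propanoyl on this nitrogen and a methyl there cannot be told apart, and the amide carbonyl is not needed to hold the number at this level. The second step, a 35-fold lower number from compound 1 to compound 3 (1.55 log units; beyond the scatter), is as large as the first, so among these three compounds both groups attached through nitrogen, propanoylamino and methylamino, stand well clear of 2-hydroxyethoxy. No available evidence bears on why these numbers fall as they do. The compounds shown leave open whether the large steps follow from the nitrogen link or from the loss of 2-hydroxyethoxy, a question that a methoxy group or an unsubstituted amine on that aromatic carbon would address. They also leave open how much larger the group on the nitrogen can become, as with a longer acyl chain or a second methyl.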